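The compounds below may be only part of what the source reports. "The series", "measured", "known", "first", "only" and "open" are said of these compounds alone.

Compound 2 `Cc1ccccc1Cn1cc(COc2ccc3c(=O)ccoc3c2)nn1` gives 15300 nM in a functional assay on HeLa cells (Homo sapiens) for cytotoxicity, read by MTT assay, with a stated time of 48 h (on this read-out higher numbers stand for weaker inhibition and lower numbers for stronger inhibition), and holds the lowest of the two numbers measured. Compound 3 `C#CCOc1ccc2c(=O)ccoc2c1` gives 64700 nM in this assay. For compound 1 `O=c1ccoc2cc(OCc3cn(Cc4cccc(Br)c4)nn3)ccc12` this assay reports only a limit, > 100000 nM. Going by the values given here, the single measured step shows an at least 6.5-fold lower number from compound 1 to compound 2 (0.81 log units; beyond the scatter), so swapping the group on the saturated chain carbon bound to an aromatic nitrogen has moved the number beyond the scatter once, although one end of that step rests on the limit (the limit of > 100000 nM in this assay, at which 1 of the 3 values shown sits). Compound 4 `COc1ccc(Cn2cc(COc3ccc4c(=O)ccoc4c3)nn2)cc1` differs from compound 2 by 4-methoxyphenyl in place of 2-methylphenyl on a saturated chain carbon bound to an aromatic nitrogen. Among the compounds with values here, no measured step tests this change directly, so a step of modest size in either direction is expected; the estimate is a 1.3-fold higher number from compound 2 to compound 4 (0.12 log units; within the scatter), giving compound 4 an expected 20000 nM, between 5000 nM and 80000 nM.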

Compound 4, half-maximal inhibitory concentration: 14400 nM
Compound 4: the middle estimate sits 1.4-fold (0.14 log units) above what was measured; low and high end bracket the measured number.
By their numbers in this assay, from the lowest: compounds 4 and 2 (each within the scatter of the next); then compound 3. At a limit, above all of these: compound 1.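

Exchanging 2-methylphenyl for 4-methoxyphenyl on a saturated chain carbon bound to an aromatic nitrogen gives a 1.1-fold lower number from compound 2 to compound 4 (0.03 log units; within the scatter), so in this assay these two different groups read alike. Compared with 3-bromophenyl, the same group gives an at least 6.9-fold lower number from compound 1 to compound 4 (0.84 log units; beyond the scatter), so compound 2 is no longer the only compound shown to lie clear of compound 1. This second step also rests on a limit: the limit of > 100000 nM in this assay, at which 1 of the 4 values shown sits.

Going by these compounds, the true size of both steps from compound 1 remains open. So does the effect of replacing the phenyl ring at this place with an amine or a carboxylic acid.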